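This account rests on a few compounds, and the source may have more. Where it says the series, first, only, none or still open, it means among the compounds named here.

Compound 1 `COc1ccc(CN(C(=O)C2CC2)c2cc(OC)c(OC)c(OC)c2)cc1O` stands lowest of the two numbers recorded in a functional assay on MGC-803 cells (Homo sapiens) for inhibition, read by MTT assay, with a stated time of 48 h; a lower number here means a stronger inhibitor, a higher number a weaker inhibitor: compound 1 gives 59 nM, whereas compound 2 `C/C=C/C(=O)N(Cc1ccc(OC)c(N)c1)c1cc(OC)c(OC)c(OC)c1` gives 150 nM, a gap beyond the usual scatter. Compound 3 `COc1cc(NCc2ccc(Cl)cc2)cc(OC)c1OC` gives only > 80000 nM, which is a limit of the assay and not a number, namely (the limit of > 80000 nM in this assay, at which 1 of the 3 values shown sits). Compound 4 `CC/C=C/C(=O)N(Cc1ccc(OC)c(O)c1)c1cc(OC)c(OC)c(OC)c1` has not yet been tested in this assay. It differs from compound 1 in one place: but-1-en-1-yl in place of cyclopropyl on a carbonyl carbon. Among the compounds with values here, no pair of measured compounds shows this change on its own, so the step is expected to be small, in either direction, and probably within the scatter. Compound 4 is therefore estimated at 80 nM, between 30 nM and 250 nM. The expected step is a 1.4-fold higher number from compound 1 to compound 4 (0.13 log units; within the scatter).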

Compound 4, half-maximal inhibitory concentration: 58 nM
The estimate for compound 4 lay 1.4-fold (0.14 log units) above the measured number, within the range that was stated.
By their numbers in this assay, from the lowest: compounds 4 and 1 (each within the scatter of the next); then compound 2. At a limit, above all of these: compound 3.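

On the carbonyl carbon, whose other neighbours are an amide-type nitrogen, the three-membered ring of cyclopropyl gives way to the open but-1-en-1-yl chain with no change in the reading in this assay: the swap gives a 1.0-fold lower number from compound 1 to compound 4 (0.01 log units; within the scatter). At this place, then, the ring is not required for a number of this size, at least for this one open chain. Nothing shown bears on why the two groups read alike. As far as these compounds go, whether an amine, a carboxylic acid or a saturated butyl chain on the same carbonyl carbon would keep that number remains open.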